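The source may hold more compounds than are shown below. What is called first, only, known or untested is meant among the compounds shown, and "the series" means these compounds.

Measured in an ADME assay on the whole organism (Rattus norvegicus, strain Sprague-Dawley) for pharmacokinetics, read by LC-MS, with a stated time of 24 h, at a dose of 5 mg/kg by the intravenous route; on this read-out higher numbers stand for wider distribution into tissues and lower numbers for narrower distribution:
compound 1 `COc1ccc(NC(=O)Nc2ccc(Oc3ncnc4cc(N(C)C)ccc34)cc2)cc1`: 0.7 L/kg
compound 2 `CN(C)c1ccc2c(Oc3ccc(NC(=O)NCc4ccc(F)cc4)cc3)ncnc2c1`: 1.4 L/kg
compound 3 `Cc1ccc(CNC(=O)Nc2ccc(Oc3ncnc4cc(N(C)C)ccc34)cc2)cn1`: 1.5 L/kg

Compound 2 stands second highest of these three numbers. Its nearest neighbour is compound 3, reached by a 1.1-fold higher number from compound 2 to compound 3 (0.03 log units; within the scatter), while the step of a 2.0-fold higher number from compound 1 to compound 2 (0.30 log units; within the scatter) separates it from compound 1. Compound 4 `COc1ccc(CNC(=O)Nc2ccc(Oc3ncnc4cc(N(C)C)ccc34)cc2)cn1` is the one to be estimated. It differs from compound 2 in a single place: 6-methoxypyridin-3-yl in place of 4-fluorophenyl on a saturated chain carbon bound to an amide-type nitrogen. The step that bears on this is the change made in the same place, a 1.1-fold higher number from compound 2 to compound 3 (0.03 log units; within the scatter), where 6-methylpyridin-3-yl replaced 4-fluorophenyl and the two numbers lie within the scatter of each other; the related step of a 2.1-fold higher number from compound 1 to compound 3 (0.33 log units; beyond the scatter) was only modest. A step no larger than the scatter is therefore expected for a 1.1-fold higher number from compound 2 to compound 4 (0.03 log units; within the scatter). Compound 4 is estimated at 1.5 L/kg, between 0.9 L/kg and 2.6 L/kg.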

Compound 4, volume of distribution at steady state: 1.4 L/kg
The estimate for compound 4 lay 1.1-fold (0.03 log units) above the measured number, and the stated range covers the measured number.
By their numbers in this assay, from the lowest: compounds 1, 2, 4 and 3 (each within the scatter of the next, the first and the last beyond it).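

In this assay, 6-methoxypyridin-3-yl in place of 4-fluorophenyl gives no change at the digits printed from compound 2 to compound 4 (within the scatter), and methoxy in place of methyl on an aromatic carbon gives a 1.1-fold lower number from compound 3 to compound 4 (0.03 log units; within the scatter). This place, on a saturated chain carbon bound to an amide-type nitrogen, has now carried three different aromatic rings in compound 2, compound 3 and compound 4, with all three numbers within the scatter of each other. The longer comparison, a 2.0-fold higher number from compound 1 to compound 4 (0.30 log units; within the scatter), also stays within the scatter. Nothing available explains these numbers. As far as these compounds go, whether an amine, a carboxylic acid or a longer chain in this place would shift the number remains open.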